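The source may hold more compounds than are shown below. What is called first, only, known or untested is meant among the compounds shown, and "the series" means these compounds.

Notes on the series. Compound 1 `N#Cc1ccc(Nc2nc(Oc3ccnc4ccccc34)nc(N3CCN(c4ccc(F)cc4)CC3)n2)cc1C(F)(F)F` gives only a limit in a functional assay on DU-145 cells (Homo sapiens) for cytotoxicity, read by sulforhodamine B assay, with a stated time of 48 h; on this read-out lower numbers stand for higher toxicity in this test and higher numbers for lower toxicity in this test: it reads > 100000 nM, a limit of the assay rather than a number. Compound 2 `CCN1CCN(c2nc(Nc3ccc(C#N)c(C(F)(F)F)c3)nc(Oc3ccnc4ccccc34)n2)CC1` likewise gives the limit > 100000 nM. Compound 3 `N#Cc1ccc(Nc2nc(Oc3ccnc4ccccc34)nc(N3CCC(Cc4ccccc4)CC3)n2)cc1C(F)(F)F` gives the limit > 100000 nM. Within the data shown here, the one measured step, a step that the two limits leave unreadable from compound 1 to compound 2, is unreadable from the two limits; the only evidence is the limit of > 100000 nM in this assay, at which 3 of the 3 values shown sit, the limit at which all three values sit. Compound 4 `N#Cc1ccc(Nc2nc(Oc3ccnc4ccccc34)nc(N3CCN(c4ccccc4F)CC3)n2)cc1C(F)(F)F` differs from compound 1 as 2-fluorophenyl in place of 4-fluorophenyl on an amine nitrogen in a ring. Among the measured compounds shown here, no measured step bears on this change, so no step beyond the scatter is expected in this assay. Compound 4 is expected to give 100000 nM, within 30000 nM to 300000 nM. The expected step is a number no higher from compound 1 to compound 4 (the limit leaves the size open), most likely a limit again.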

Compound 4, concentration lethal to 50% of the cells: > 100000 nM
Compound 4: no number, only a limit; the forecaster's own chance of this, stated with the estimate: 85%; the middle value sits exactly at the limit.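

Among these compounds, compound 4 gives > 100000 nM, again a limit of the assay, so no step to it from compound 1 or compound 2 can be read. The compounds shown leave open whether any group at this place gives a measurable value in this assay.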